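Carbamate series: trifluoromethoxy in place of fluoro on the benzoyl ring

A few compounds are considered here, and "the series" means these few. Any claim that something is new, unique, unknown or untested is made for them only; others in the source may bear on it.

Two compounds of this series have numbers in a functional assay on cells for antagonist activity at prostaglandin D2 receptor 2 (Homo sapiens), read by chemiluminescence and beta-arrestin recruitment, with stated times of 30 min and 60 min; a lower number here means a stronger inhibitor, a higher number a weaker inhibitor. Compound 1 `O=C(O)CCC(=O)N(C1CC1)[C@H]1c2ccccc2N(C(=O)c2ccc(OC(F)(F)F)cc2)[C@H]2CC[C@H]21` gives 24 nM in this assay. Compound 2 `O=C(O)COC(=O)N(C1CC1)[C@H]1c2ccccc2N(C(=O)c2ccc(F)cc2)[C@H]2CC[C@H]21` gives 1.4 nM in this assay, the lowest of the two numbers, and the gap to compound 1 lies beyond the scatter. Compound 1 and compound 2 differ in more than one place, so the gap between them cannot be assigned to a single change.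

Compound 3 `O=C(O)COC(=O)N(C1CC1)[C@H]1c2ccccc2N(C(=O)c2ccc(OC(F)(F)F)cc2)[C@H]2CC[C@H]21` keeps the whole of compound 2 except for one change: trifluoromethoxy in place of fluoro on an aromatic carbon. The same trifluoromethoxy group is present in compound 1, but compound 1 also carries a different acid-bearing side chain, so the two measured numbers give no clean reading of this change on its own.

Given that, the step from compound 2 to compound 3 in this assay is expected to be small, most likely a modest rise in the number or no change beyond the scatter, as a 1.8-fold higher number from compound 2 to compound 3 (0.25 log units; within the scatter). The estimate for compound 3 in this assay is 2.5 nM, with a range from 0.7 nM to 9 nM.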

Compound 3, half-maximal inhibitory concentration: 1.4 nM
Estimate against measurement, compound 3: 1.8-fold (0.25 log units) above; the range from low to high includes it.
By their numbers in this assay, from the lowest: compounds 2 and 3 (each within the scatter of the next); then compound 1.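

Trifluoromethoxy in place of fluoro on this aromatic carbon gives no change at the digits printed from compound 2 to compound 3 (within the scatter) in this assay, so with the carboxymethoxy side chain in place, the position accepts a group of 5 heavy atoms in place of a single fluorine with no reading in this assay. Compound 3 also gives the series its first single-change comparison at the side chain: with trifluoromethoxy held constant, carboxymethoxy in place of 2-carboxyethyl on the carbonyl carbon gives a 17-fold lower number from compound 1 to compound 3 (1.23 log units; beyond the scatter), a large step. The gap between compound 1 and compound 2, which could not be assigned earlier, therefore tracks the side chain in these three compounds, although nothing shown here accounts for either step.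

Within the data shown here, the aromatic position is read with only two groups, both alongside the carboxymethoxy side chain, so it remains open whether a dimethylamino group or a nitrile there would leave the number unchanged. On these data alone, it is also open whether the side-chain step carries over with fluoro on the ring, and how a longer chain ending in a carboxylic acid would read.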